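Chloro added to the anilino ring of a triazine

This account rests on a few compounds, and the source may have more. Where it says the series, first, only, none or still open, it means among the compounds named here.

In a functional assay on the whole organism (strain Swiss) for inhibition, with Mus musculus as the target, with a stated time of 30 min, at a dose of 5 mg/kg by the intraperitoneal route (a lower number here means a weaker effect, a higher number a stronger effect of the compound at the dose given), two compounds have been measured. Compound 2 `O=C1COCCN1c1ccc(Nc2nc(Cl)nc(Nc3ccccc3)n2)cc1` gives 76% and compound 1 `Nc1nc(Cl)nc(Nc2ccc(N3CCOCC3=O)cc2)n1` gives 67%; the step of a number 9 percentage points higher from compound 1 to compound 2 (within the scatter) lies within the scatter, so the two cannot be told apart. Compound 3 `O=C1COCCN1c1ccc(Nc2nc(Cl)nc(Nc3ccc(Cl)cc3)n2)cc1` differs from compound 2 by chloro in place of hydrogen on an aromatic carbon. Among the measured compounds shown here, no measured step touches this position, and the one step known, phenyl in place of hydrogen on a nitrogen on an aromatic ring, stayed within the scatter. For compound 3 the expected step is no change at the digits printed from compound 2 to compound 3 (within the scatter), none beyond the scatter. Compound 3 is therefore estimated at 76%, between 55% and 90%.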

Compound 3, a percentage reported as inhibition, in the whole organism at one dose (the size of the read-out at that dose, not a potency): 79%
Compound 3: middle estimate off by 3 percentage points, on the low side; the measured number falls inside the stated range.
By their numbers in this assay, from the lowest: compounds 1, 2 and 3 (each within the scatter of the next, the first and the last beyond it).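

In this assay, chloro on the aromatic carbon gives a number 3 percentage points higher from compound 2 to compound 3 (within the scatter) and so leaves the effect at this dose unchanged within the scatter. Set against the compound with only hydrogen on that nitrogen, the 4-chlorophenyl group gives a number 12 percentage points higher from compound 1 to compound 3 (beyond the scatter) and this is the first step here beyond the scatter, though a modest one. Nothing at hand explains either step. Still open, as far as these compounds go, is whether fluoro, methoxy or an amine at the same place would behave like chloro. A single dose also shows only the size of the effect at that dose and leaves open how these compounds would compare at any other dose.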